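The source may hold more compounds than are shown below. What is called first, only, known or untested is meant among the compounds shown, and "the series" means these compounds.

Measured compounds:
Compound 1, `CCCNc1cccnc1-c1ccc(C(=O)Nc2ccc(C(C)(C)C)cc2)cc1`: in a functional assay for antagonist activity at transient receptor potential cation channel subfamily V member 1 (Homo sapiens), read by FLIPR (on this read-out higher numbers stand for weaker inhibition and lower numbers for stronger inhibition), compound 1 gives 158 nM.
Compound 2, `CC(C)(C)c1ccc(NC(=O)c2ccc(-c3ncccc3NS(=O)(=O)c3ccccc3)cc2)cc1`: in this assay compound 2 gives 91 nM.
Compound 3, `O=C(Nc1ccc(C(F)(F)F)cc1)c1ccc(-c2ncccc2C(F)(F)F)cc1Cl`: in this assay compound 3 reaches only the limit of the assay, > 4000 nM, which is not a number.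

Compound 3 therefore stands apart from the other two: where compounds 1 and 2 return numbers, compound 3 gives only a limit, and the limit of > 4000 nM in this assay, at which 1 of the 3 values shown sits, is the only such limit among the three values shown. Compound 4, `COc1cc(-c2ncccc2C(F)(F)F)ccc1C(=O)Nc1ccc(C(F)(F)F)cc1`, is not yet measured. It differs from compound 3 in one place: methoxy in place of chloro on an aromatic carbon. Among the compounds with values here, only one measured step exists, a 1.7-fold lower number from compound 1 to compound 2 (0.24 log units; within the scatter), and that exchange concerns a different group on a nitrogen, so it bears on the present change only loosely: it shows that a single exchange on this shared core can leave the read-out within the scatter. Within the data shown here, no measured step starts from compound 3. The expectation for compound 4 thus rests mainly on where compound 3 stands, and the step is expected to be a step that the limit leaves unreadable from compound 3 to compound 4. Compound 4 is estimated at 5000 nM, with a range from 1500 nM to 30000 nM, and a fair chance that only a limit is again reported.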

Compound 4, half-maximal inhibitory concentration: > 4000 nM
Compound 4: only a limit was reported; the forecaster's own chance of this, stated with the estimate: 55%; the middle value does not contradict the limit.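

In this assay, compound 3 and compound 4 each return only a limit, not a number, so the exchange of chloro for methoxy cannot be read as a step: the limit of > 4000 nM in this assay, at which 2 of the 4 values shown sit.
The compounds shown leave open how strongly either compound inhibits the channel, and whether methoxy in place of chloro changes the read-out at all.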